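Adding a Chloro Group: Expected Cytotoxicity of Compound 4

A few compounds are considered here, and "the series" means these few. Any claim that something is new, unique, unknown or untested is made for them only; others in the source may bear on it.

Compound 1, `O=C(N/N=C/c1c(-c2cc3ccccc3oc2=O)[nH]c2ccccc12)c1ccccc1Cl`: in a toxicity assay on Vero cells (Chlorocebus sabaeus) for inhibition, read by MTT assay, with a stated time of 48 h (a lower number here means a stronger inhibitor, a higher number a weaker inhibitor), compound 1 gives > 200000 nM, a limit of the assay and not a number.
Compound 2, `O=C(N/N=C/c1c(-c2cc3ccccc3oc2=O)[nH]c2ccccc12)c1ccccc1F`: in this assay compound 2 gives > 200000 nM, again a limit of the assay.
Compound 3, `O=C(N/N=C/c1c(-c2cc3ccccc3oc2=O)[nH]c2ccccc12)c1cccc(Br)c1`: in this assay compound 3 gives > 200000 nM, also a limit of the assay.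

Compound 2 therefore stands only at a limit, and so do its two neighbours: the limit of > 200000 nM in this assay, at which 3 of the 3 values shown sit. Every step among the measured compounds is accordingly unreadable. From compound 1 to compound 2 the step is a step that the two limits leave unreadable from compound 1 to compound 2; from compound 1 to compound 3 it is a step that the two limits leave unreadable from compound 1 to compound 3; from compound 2 to compound 3 it is a step that the two limits leave unreadable from compound 2 to compound 3. None of them shows whether any change on this part of the shared core moves the read-out at all.

Compound 4, `O=C(N/N=C/c1c(-c2cc3ccccc3oc2=O)[nH]c2ccccc12)c1ccc(Cl)cc1F`, differs from compound 2 by chloro in place of hydrogen on an aromatic carbon. The three unreadable steps give no reason to expect that this change would pull the value below the limit, so compound 4 is expected to remain at or beyond it. The estimate for compound 4 in this assay is 300000 nM, with a range from 150000 nM to 1000000 nM. The step from compound 2 to compound 4 is thus expected to be a step that the limit leaves unreadable from compound 2 to compound 4, most likely reported only as a limit once more.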

Compound 4, half-maximal inhibitory concentration: > 200000 nM
Compound 4 was reported as a limit; the forecaster's own chance of this, stated with the estimate: 85%; the middle value is on the limit's open side.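

In this assay compound 4 gives > 200000 nM, a limit of the assay and not a number. No step linking compound 4 to compound 1, compound 2 or compound 3 can be read, as all four stand at one limit: the limit of > 200000 nM in this assay, at which 4 of the 4 values shown sit.

The compounds shown leave open whether any change on this part of the shared core moves the read-out at all.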